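A few compounds are considered here, and "the series" means these few. Any claim that something is new, unique, unknown or untested is made for them only; others in the source may bear on it.

Working notes on the series. The shared core of compound 1 `O=C(CSc1nnc(-c2ccncc2)o1)N/N=C/c1ccc(O)cc1` carries an aryl group on a carbon with a double bond to nitrogen, and this aryl group is the only place where the measured compounds differ. In an ADME assay on NIH3T3 cells (Mus musculus) for cytotoxicity, read by MTT assay, with a stated time of 24 h (a higher number here means a weaker inhibitor, a lower number a stronger inhibitor), compound 1 gives 158000 nM. Compound 2 `O=C(CSc1nnc(-c2ccncc2)o1)N/N=C/c1cc(Cl)ccc1O` gives 166000 nM in this assay, and compound 3 `O=C(CSc1nnc(-c2ccncc2)o1)N/N=C/c1ccc(Cl)cc1Cl` gives 221000 nM. The steps of a 1.1-fold higher number from compound 1 to compound 2 (0.02 log units; within the scatter) and a 1.4-fold higher number from compound 1 to compound 3 (0.15 log units; within the scatter) both stay within the scatter, as does a 1.3-fold higher number from compound 2 to compound 3 (0.12 log units; within the scatter), so the three measured compounds sit together and no aryl change seen so far has moved this assay.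

The next compound, compound 4 `O=C(CSc1nnc(-c2ccncc2)o1)N/N=C/c1cccs1`, differs from compound 1 as follows: thiophen-2-yl in place of 4-hydroxyphenyl on a carbon with a double bond to nitrogen. Going by the values given here, none of the measured steps carries the same change, so the expectation rests on the general picture: three different aryl groups at this position, two carrying a hydroxyl and one without, all returning numbers within the scatter of each other. On that basis the step from compound 1 is expected to be a 1.1-fold higher number from compound 1 to compound 4 (0.06 log units; within the scatter), that is, nothing beyond the scatter in either direction. Compound 4 is therefore estimated at 180000 nM in this assay, with a range from 90000 nM to 360000 nM, pending measurement.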

Compound 4, half-maximal inhibitory concentration: 189000 nM
The estimate for compound 4 lay 1.1-fold (0.02 log units) below the measured number, within the range that was stated.
By their numbers in this assay, from the lowest: compounds 1, 2, 4 and 3 (each within the scatter of the next).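

Changing the ring type at this position does not move this assay: the step is a 1.2-fold higher number from compound 1 to compound 4 (0.08 log units; within the scatter), with a 1.1-fold higher number from compound 2 to compound 4 (0.06 log units; within the scatter) and a 1.2-fold lower number from compound 3 to compound 4 (0.07 log units; within the scatter) alongside it. The earlier compounds shown here varied only the substituents on a phenyl ring, whereas compound 4 shows that a five-membered aromatic ring with 1 hetero atom, here thiophen-2-yl, can stand on the carbon with a double bond to nitrogen without a step beyond the scatter from any of the three phenyl compounds, so the flat picture now extends past phenyl groups to this sulfur-containing ring. No supporting data bear on why the number stays put at this position.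

The compounds shown leave open whether any group at this place can shift the number, since all four carry an aromatic ring with only hydroxyl or chloro substituents, or none, and a dimethylamino group or a carboxylic acid on the ring, or a saturated cyclohexyl ring or a longer alkyl chain in place of the aryl group, would test that. They also leave open how the number responds to changes elsewhere in the shared core, as every compound here keeps it intact.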